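The compounds below may be only part of what the source reports. "The series", "measured", "known", "first", "only" and "open" are said of these compounds alone.

Working notes on the series. For the measured compounds named here, in a functional assay on MDA-MB-231 cells (Homo sapiens) for inhibition, read by CCK-8 assay, with a stated time of 48 h (on this read-out higher numbers stand for weaker inhibition of growth and lower numbers for stronger inhibition of growth), compound 3 `Cc1ccccc1Nc1nc(Nc2cc(Cl)ccn2)ncc1Cl` gives 52400 nM, the only true number so far. Compound 1 `Cc1ccccc1Nc1nc(NC2CC2)ncc1Cl` reads > 100000 nM, which is a limit of the assay and not a number. Compound 2 `Cc1ccccc1Nc1nc(NC2CCCCC2)ncc1Cl` reads > 100000 nM, again a limit. The values therefore show (the limit of > 100000 nM in this assay, at which 2 of the 3 values shown sit).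

Compound 4 `Cc1ccccc1Nc1nc(NCc2ccncc2)ncc1Cl` is next, and the change is (pyridin-4-yl)methyl in place of 4-chloropyridin-2-yl on a nitrogen on an aromatic ring. In words, (pyridin-4-yl)methyl stands in place of 4-chloropyridin-2-yl on a nitrogen on an aromatic ring. Both groups hold one six-membered aromatic ring with 1 hetero atom, and the chlorine leaves.

Going by the values given here, the steps that bear on this are an at least 1.9-fold lower number from compound 1 to compound 3 (0.28 log units; that floor lies within the scatter) and an at least 1.9-fold lower number from compound 2 to compound 3 (0.28 log units; that floor lies within the scatter). Both are floors only, and neither shows a gain beyond the scatter. The remaining step, a step that the two limits leave unreadable from compound 1 to compound 2, adds nothing on size. Among the compounds with values here, no measured compound carries (pyridin-4-yl)methyl, so the expectation in this assay is no step beyond the scatter, leaning toward a higher number and with a real chance of a limit. The expected size is a 1.3-fold higher number from compound 3 to compound 4 (0.13 log units; within the scatter). For compound 4 the estimated value is 70000 nM, with an expected range of 25000 nM to 100000 nM.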

Compound 4, concentration for 50% growth inhibition: > 100000 nM
Compound 4 ended at the assay's limit; the forecaster's own chance of this, stated with the estimate: 45%; middle value at least 1.4-fold (0.15 log units) away from the limit.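

In this assay compound 4 reads > 100000 nM, which is a limit of the assay and not a number. For the compounds shown here, with (pyridin-4-yl)methyl in place of 4-chloropyridin-2-yl on the nitrogen, the result is an at least 1.9-fold higher number from compound 3 to compound 4 (0.28 log units; that floor lies within the scatter), so a six-membered aromatic ring with 1 hetero atom on that nitrogen does not by itself keep a value off the limit, something the earlier compounds could not show. The steps from compound 1 and from compound 2 to compound 4 cannot be read, and the series still rests mostly on one edge of the read-out: the limit of > 100000 nM in this assay, at which 3 of the 4 values shown sit.

From the compounds shown here alone, the true size of the step remains open, and so does whether the loss of the chlorine or the added carbon link between the nitrogen and the ring matters more, a question that pyridin-2-yl or (4-chloropyridin-2-yl)methyl on the same nitrogen would separate. Also open, going by these compounds, is how a chain ending in an amine, such as 2-(dimethylamino)ethyl, would read there in this assay.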